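A few compounds are considered here, and "the series" means these few. Any claim that something is new, unique, unknown or untested is made for them only; others in the source may bear on it.

Working notes on the series. The shared core of compound 1 `COc1cc2cc(Oc3ccc(NC(=O)Nc4cccc(C(F)(F)F)c4)cc3)c(C)nc2cc1OC` carries a urea-linked aryl group on which the substitution is varied. In a functional assay on SNB-19 cells (Homo sapiens) for inhibition, read by sulforhodamine B assay, with a stated time of 48 h, tested at 10 uM (on this read-out higher numbers stand for a weaker effect at the one concentration tested and lower numbers for a stronger effect), compound 1 gives 31.4%. Compound 2 `COc1cc2cc(Oc3ccc(NC(=O)Nc4ccc(Cl)c(C(F)(F)F)c4)cc3)c(C)nc2cc1OC` adds a chloro group to that aryl ring; in this assay compound 2 gives 23.7%, and the change a number 7.7 percentage points lower from compound 1 to compound 2 (within the scatter) stays within the scatter, so compound 2 and compound 1 stand together on these numbers, with nothing to separate them.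

Compound 3 `COc1cc2cc(Oc3ccc(NC(=O)Nc4ccc(Cl)c(Cl)c4)cc3)c(C)nc2cc1OC` is the next step: chloro in place of trifluoromethyl on an aromatic carbon. For the measured compounds named here, no measured step exchanges trifluoromethyl for chloro, so nothing bears on it directly; the only step known, from compound 1 to compound 2, was within the scatter and touched a different position. Going by the values given here, with no step on record beyond the scatter, no shift beyond the scatter is expected for compound 3 in this assay either, and the step of a number 1.3 percentage points higher from compound 2 to compound 3 (within the scatter) is estimated to be small. Compound 3 is therefore expected to give about 25% in this assay, with a range from 8% to 42%.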

Compound 3, a percentage reported as activity, at one concentration (the size of the read-out at that concentration, not a potency): 28.7%
Compound 3: middle estimate off by 3.7 percentage points, on the low side, and the stated range covers the measured number.
By their numbers in this assay, from the lowest: compounds 2, 3 and 1 (each within the scatter of the next).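

On this assay the position that carries trifluoromethyl in compound 2 also takes chloro, one heavy atom in place of four, with a number 5 percentage points higher from compound 2 to compound 3 (within the scatter) and no separation between the two groups on this read-out. This is the first step in the series made at that position itself rather than at the neighbouring chloro site of the earlier step, and the wider comparison, with a number 2.7 percentage points lower from compound 1 to compound 3 (within the scatter) for 3,4-dichlorophenyl in place of 3-(trifluoromethyl)phenyl on the amide-type nitrogen, also leaves the compounds together, so the three aryl groups shown cannot be told apart at the one concentration tested. Nothing on hand speaks to why these groups read alike.

On these data alone, it remains open whether this aromatic carbon accepts groups of another kind, such as a methoxy group, a nitrile, an amine or a carboxylic acid, with numbers that still stand with those of compound 2 and compound 3 or that move beyond the scatter. A read-out at a single concentration also gives no potency, so any difference among these three compounds that would show up across a range of concentrations stays unresolved.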